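The compounds below may be only part of what the source reports. "The series", "measured", "known", "first", "only" and "open" are said of these compounds alone.

In a functional assay on MKN-45 cells (Homo sapiens) for cytotoxicity (a lower number here means a stronger inhibitor, a higher number a weaker inhibitor), compound 2 `COc1ccc(S(=O)(=O)N2CCc3cccc(NC(=O)Oc4ccccc4)c32)cc1` gives > 10000 nM, which is a limit of the assay and not a number. Its standing is no more than this: the limit of > 10000 nM in this assay, at which 1 of the 3 values shown sits. In the same assay, compound 1 `COC(=O)c1ccc(C(=O)Nc2cccc3c2N(S(=O)(=O)c2ccc(OC)cc2)CC3)cc1` gives 312 nM, and compound 3 `COc1ccc(S(=O)(=O)N2CCc3cccc(NC(=O)c4ccc([N+](=O)[O-])cc4)c32)cc1` gives 95 nM.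

Compound 4 `COc1ccc(S(=O)(=O)N2CCc3cccc(NCc4ccccc4)c32)cc1` has benzyl in place of phenoxycarbonyl on a nitrogen on an aromatic ring. The nearest evidence comes from exchanges on the carbonyl carbon. Both an at least 32-fold higher number from compound 1 to compound 2 (1.50 log units; beyond the scatter) and an at least 100-fold lower number from compound 2 to compound 3 (2.02 log units; beyond the scatter) are large, while a 3.3-fold lower number from compound 1 to compound 3 (0.52 log units; beyond the scatter) is modest. None of these steps removes the carbonyl, as the change to compound 4 does, so they bear on it only loosely. They show that leaving phenoxy behind can matter greatly, so a lower number is expected, though a smaller change than an at least 100-fold lower number from compound 2 to compound 3 (2.02 log units; beyond the scatter) seems likely and a second limit remains possible. The expected step is an at least 3.3-fold lower number from compound 2 to compound 4 (0.52 log units; beyond the scatter). For compound 4 the estimated value is 3000 nM, with an expected range from 300 nM to 10000 nM.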

Compound 4, half-maximal inhibitory concentration: > 10000 nM
Compound 4: only a limit was reported; the forecaster's own chance of this, stated with the estimate: 35%; at least 3.3-fold (0.52 log units) between middle value and limit.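

Among these compounds, compound 2 and compound 4 both sit at a limit of the assay rather than at a number, so no step between them can be read: the limit of > 10000 nM in this assay, at which 2 of the 4 values shown sit.

The compounds shown leave open whether benzyl in place of phenoxycarbonyl on this nitrogen changes the read-out at all.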